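From 3-Fluorophenyl to 4-Cyanophenyl on a Shared Core

The compounds below may be only part of what the source reports. "The series", "measured", "known", "first", "only" and "open" are said of these compounds alone.

Compound 1 `C[C@H](Nc1ncnc2[nH]cnc12)c1nn(-c2cccnc2)c2cc(Cl)ccc12`: > 40000 nM
Compound 2 `C[C@H](Nc1ncnc2[nH]cnc12)c1nn(-c2cccc(F)c2)c2cc(F)ccc12`: > 40000 nM

Both compounds were tested in a functional assay on Bel-7402 cells (Homo sapiens) for inhibition, read by sulforhodamine B assay, with a stated time of 72 h; a higher number here means a weaker inhibitor, a lower number a stronger inhibitor. In this assay compound 1 gives > 40000 nM, which is a limit of the assay and not a number. Compound 2 gives > 40000 nM, which is likewise a limit and not a number. Compound 2 therefore stands with compound 1 at the only mark reached so far: the limit of > 40000 nM in this assay, at which 2 of the 2 values shown sit.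

The next compound to be measured is compound 3 `C[C@H](Nc1ncnc2[nH]cnc12)c1nn(-c2ccc(C#N)cc2)c2cc(F)ccc12`, which keeps the shared core and changes one group: 4-cyanophenyl in place of 3-fluorophenyl on an aromatic nitrogen. The 4-cyanophenyl takes the place of the 3-fluorophenyl on the aromatic nitrogen. Among the compounds with values here, the data hold no step between measured compounds to serve as a guide. The expectation rests on compound 2 and its limit of > 40000 nM, and no change beyond the scatter is expected in this assay. The expected change is a number no higher from compound 2 to compound 3 (the limit leaves the size open). For compound 3 the estimated value is 40000 nM, with an expected range from 15000 nM to 80000 nM.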

Compound 3, half-maximal inhibitory concentration: 31500 nM
Compound 3: middle estimate off by 1.3-fold (0.10 log units), on the high side; low and high end bracket the measured number.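

In this assay, within the data shown here, compound 3 gives 31500 nM, the first reading that is a number and not a limit, so the shared core with this group on the aromatic nitrogen now has a measured value to compare against. Setting 4-cyanophenyl in place of 3-fluorophenyl at this position, on the aromatic nitrogen of the five-membered ring, gives an at least 1.2-fold lower number from compound 2 to compound 3 (0.10 log units; that floor lies within the scatter), and this is the first step that can be read at this position, though only as a floor. The value of compound 2 is a limit and not a number, and the true size of the step stays unknown because of that limit: the limit of > 40000 nM in this assay, at which 2 of the 3 values shown sit.

The compounds shown leave open whether the nitrile itself matters here or whether any other group at this position would serve as well, and a 4-aminophenyl, a 4-carboxyphenyl or a 4-methoxyphenyl on the same nitrogen would speak to that. They also leave open whether the 4-cyanophenyl would give a similar reading on the core of compound 1, which carries chlorine in place of fluorine.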